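Removing One Fluoro Group From a Compound at the Assay Limit

This account rests on a few compounds, and the source may have more. Where it says the series, first, only, none or still open, it means among the compounds named here.

Measured compounds:
Compound 1 `Cn1c(-c2cccc(F)c2)nnc1S(C)(=O)=O`: > 200 mg/kg
Compound 2 `CSc1n[nH]c(-c2ccc(F)cc2)n1`: > 200 mg/kg
Compound 3 `Cn1c(-c2cccs2)nnc1S(C)(=O)=O`: > 200 mg/kg

These three results come from a functional assay on the whole organism for antagonist activity, with Mus musculus as the target; a higher number here means that more compound is needed for the effect, a lower number that less compound is needed. Compound 1 gives > 200 mg/kg, which is a limit of the assay and not a number. The picture is the same across the set, with the limit of > 200 mg/kg in this assay, at which 3 of the 3 values shown sit. None of the three compounds therefore has an exact dose, and no order among them can be read from these results.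

The next compound to be measured is compound 4 `Cn1c(-c2ccccc2)nnc1S(C)(=O)=O`. It is made from compound 1 by one structural change: hydrogen in place of fluoro on an aromatic carbon. In words, hydrogen stands in place of fluoro on an aromatic carbon.

For the measured compounds named here, no two measured compounds differ in only one place, so the data offer no direct measure of what this change does in this assay. With only limits to go on, no step beyond the usual scatter is expected, and no direction can be favoured. The estimated a number no higher from compound 1 to compound 4 (the limit leaves the size open) reflects that expectation. For compound 4 the expected dose is 200 mg/kg, with an estimated range from 100 mg/kg to 400 mg/kg.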

Compound 4, dose for half-maximal effect: > 200 mg/kg
Compound 4: a limit, no number (the forecaster's own chance of this, stated with the estimate: 65%); the middle value sits exactly at the limit.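

In this assay compound 4 gives > 200 mg/kg, which is a limit of the assay and not a number. No step can be read between compound 1 and compound 4, because both results are limits: the limit of > 200 mg/kg in this assay, at which 4 of the 4 values shown sit.

The compounds shown leave open whether hydrogen in place of fluoro changes the dose needed, and what dose any of these compounds requires.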